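A few compounds are considered here, and "the series" means these few. Any claim that something is new, unique, unknown or untested is made for them only; others in the source may bear on it.

Compound 1 `O=C(/C=C/CN1CCCCC1)Nc1cc2c(Nc3ccc(F)c(Cl)c3)ncnc2cc1O[C@H]1CCOC1`: 168 nM
Compound 2 `C#Cc1cccc(Nc2ncnc3cc(O[C@H]4CCOC4)c(NC(=O)/C=C/CN4CCCCC4)cc23)c1`: 40.1 nM

In a functional assay on NCI-H1975 cells (Homo sapiens) for inhibition (on this read-out lower numbers stand for stronger inhibition of growth and higher numbers for weaker inhibition of growth), compound 2 gives the lower of the two numbers. Among the measured compounds shown here, the only measured step, a 4.2-fold lower number from compound 1 to compound 2 (0.62 log units; beyond the scatter), concerns the group on the aryl amine nitrogen and nothing else. Compound 3 `C#Cc1cccc(Nc2ncnc3cc(O[C@H]4CCOC4)c(NC(=O)/C=C/CNC(C)C)cc23)c1` differs from compound 2 by isopropylamino in place of piperidin-1-yl on a saturated chain carbon bound to a double-bonded chain carbon. For the measured compounds named here, no measured step touches this end of the chain, so the data give no guide for the size of the change. The step from compound 2 to compound 3 is therefore expected to stay within the scatter, a 1.2-fold higher number from compound 2 to compound 3 (0.10 log units; within the scatter). Compound 3 is estimated at 50 nM, in a range from 18 nM to 140 nM.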

Compound 3, concentration for 50% growth inhibition: 19.8 nM
Estimate against measurement, compound 3: 2.5-fold (0.40 log units) above; the range from low to high includes it.
By their numbers in this assay, from the lowest: compound 3; then compound 2; then compound 1.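

At this end of the chain the group does change the result in this assay: isopropylamino in place of piperidin-1-yl gives a 2.0-fold lower number from compound 2 to compound 3 (0.31 log units; beyond the scatter). The ring is therefore not needed here, and an open group with fewer heavy atoms and one hydrogen-bond donor serves at least as well. No measurement at hand explains this step. Still open, as far as these compounds go, is whether losing the ring or adding the donor drives the step; cyclopentylamino, which has both a ring and a donor, and dimethylamino, which has neither, would separate the two.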